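Chloro scan on the shared core of compound 1

A few compounds are considered here, and "the series" means these few. Any claim that something is new, unique, unknown or untested is made for them only; others in the source may bear on it.

Compound 1 `CN1C(=O)C2(C(C#N)=C(N)Oc3cc4oc(-c5ccccc5)cc(=O)c4c(O)c32)c2ccccc21` is the parent of this short set. In a functional assay on K562 cells (Homo sapiens) for antiproliferative activity, read by MTT assay, with a stated time of 48 h (a higher number here means a weaker inhibitor, a lower number a stronger inhibitor), compound 1 gives only a limit, > 50000 nM, and no number. Compound 2 `Cc1ccc2c(c1)C1(C(=O)N2C)C(C#N)=C(N)Oc2cc3oc(-c4ccccc4)cc(=O)c3c(O)c21`, methyl in place of hydrogen on an aromatic carbon, gives 5870 nM in this assay, a step of an at least 8.5-fold lower number from compound 1 to compound 2 (0.93 log units; beyond the scatter). Compound 3 `CN1C(=O)C2(C(C#N)=C(N)Oc3cc4oc(-c5ccccc5)cc(=O)c4c(O)c32)c2cccc(Cl)c21`, chloro in place of hydrogen on an aromatic carbon, gives 41400 nM in this assay, a step of an at least 1.2-fold lower number from compound 1 to compound 3 (0.08 log units; that floor lies within the scatter), which stays within the scatter.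

Compound 4 `CN1C(=O)C2(C(C#N)=C(N)Oc3cc4oc(-c5ccccc5)cc(=O)c4c(O)c32)c2cc(Cl)ccc21` carries the same change at another place: chloro in place of hydrogen on an aromatic carbon. The step from compound 1 to compound 3 is the one that bears directly on it, being the same group on the same ring, and it gave a number that barely moved from the limit; the methyl step of compound 2 is the only one that went beyond the scatter. The expectation for compound 4 in this assay is therefore a weak inhibitor with a step of an at least 1.4-fold lower number from compound 1 to compound 4 (0.15 log units; that floor lies within the scatter), possibly again only a limit. Compound 4 is estimated at 35000 nM, in the range 8000 nM to 100000 nM.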

Compound 4, half-maximal inhibitory concentration: 4340 nM
Estimate against measurement, compound 4: 8.1-fold (0.91 log units) above; measured number outside the range, below it.
By their numbers in this assay, from the lowest: compounds 4 and 2 (each within the scatter of the next); then compound 3. At a limit, above all of these: compound 1.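

In this assay, chloro in place of hydrogen at this place, meta to a fused ring and para to a fused ring, gives an at least 11-fold lower number from compound 1 to compound 4 (1.06 log units; beyond the scatter) and so goes beyond the scatter, whereas the same group elsewhere on the ring left compound 3 at 41400 nM. Where chloro stands on this ring therefore counts in this set, and at this place the group can replace methyl with a 1.4-fold lower number from compound 2 to compound 4 (0.13 log units; within the scatter), so the two groups are not told apart here. The first of these steps is only a floor, since compound 1 stands at a limit: the limit of > 50000 nM in this assay, at which 1 of the 4 values shown sits.

On these data alone, it remains open whether the number at this place follows from chloro and methyl alone or would also hold for bromo, methoxy or an amine. As far as these compounds go, a carboxylic acid at this place is equally open.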